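Swapping an aryl group for a chloropropyl chain on the triazole

The source may report more compounds than this note shows. Statements on the series, on what has been measured and on what is new or still open speak of the compounds shown alone.

Of the compounds shown here, three sharing one core have been tested in a functional assay on HeLa cells (Homo sapiens) for antiproliferative activity, read by MTT assay, with a stated time of 72 h; on this read-out higher numbers stand for weaker inhibition and lower numbers for stronger inhibition. Compound 1 `O=C1O/C(=C\Cn2cc(-c3ccc(Br)cc3)nn2)C(OCc2ccccc2)=C1OCc1ccccc1` gives 24300 nM. Compound 2 `Cc1ccc(-c2cn(C/C=C3\OC(=O)C(OCc4ccccc4)=C3OCc3ccccc3)nn2)cc1` gives 7480 nM. Compound 3 `CCCCCc1ccc(-c2cn(C[C@H](O)[C@H]3OC(=O)C(OCc4ccccc4)=C3OCc3ccccc3)nn2)cc1` gives 8390 nM. Among these three numbers compound 3 stands second highest: its gap to compound 2 lies within the scatter of repeated measurements, while its number is clearly lower than that of compound 1. Among the compounds with values here, the only step between neighbours that differ in one place is a 3.2-fold lower number from compound 1 to compound 2 (0.51 log units; beyond the scatter), which shows that exchanging the small group on the aromatic ring moves the number by a modest amount.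

Compound 4 `O=C1O[C@H]([C@@H](O)Cn2cc(CCCCl)nn2)C(OCc2ccccc2)=C1OCc1ccccc1` is not yet measured. It differs from compound 3 by 3-chloropropyl in place of 4-pentylphenyl on an aromatic carbon. Within the data shown here, no measured pair follows this kind of exchange, in which a whole aromatic ring with its chain is replaced by a short chain, so the one known step offers only a loose guide. Because compound 3 already gives 8390 nM, and the group that leaves is large while the group that enters is small, a move toward a higher number is expected, estimated as a 2.4-fold higher number from compound 3 to compound 4 (0.38 log units; beyond the scatter) in this assay. Compound 4 is therefore expected to give about 20000 nM, within a range from 6000 nM to 60000 nM.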

Compound 4, half-maximal inhibitory concentration: 36700 nM
Compound 4: the middle estimate sits 1.8-fold (0.26 log units) below what was measured; measured number inside the range.
By their numbers in this assay, from the lowest: compounds 2 and 3 (each within the scatter of the next); then compounds 1 and 4 (each within the scatter of the next).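

On the aromatic carbon of the five-membered ring with 3 nitrogen, putting 3-chloropropyl in place of 4-pentylphenyl in this assay gives a 4.4-fold higher number from compound 3 to compound 4 (0.64 log units; beyond the scatter), a modest change but one beyond the scatter. The earlier step exchanged only a small group and kept the aromatic ring on this carbon, whereas this one removes the ring and its chain together, and it shows that the number also responds to this larger change at this position. No measurement shown here accounts for the rise, and a single step cannot separate the loss of the ring, the loss of the pentyl chain and the arrival of the chlorine.

Those three parts could be told apart by an unsubstituted phenyl group, a plain pentyl chain or a propyl chain ending in an amine instead of chlorine on the same carbon. Also open, going by these compounds, is whether the same exchange would shift the number by a similar amount on the core shared by compound 1 and compound 2, which differs from that of compound 3 and compound 4.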